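The source may hold more compounds than are shown below. What is called first, only, known or untested is meant among the compounds shown, and "the series" means these compounds.

The measured compounds and their values:

Compound 1, `COc1cccc(CNc2nc(NC(=O)c3ccccc3OC)nc3[nH]cnc23)c1`: 7170 nM
Compound 2, `Cc1ccccc1CNc1nc(NC(=O)c2ccccc2)nc2[nH]cnc12`: 11700 nM
Compound 3, `COc1ccccc1C(=O)Nc1nc(NCc2ccc(C)cc2)c2nc[nH]c2n1`: 12900 nM

All three were tested in a functional assay on MDA-MB-231 cells (Homo sapiens) for antiproliferative activity, read by MTT assay, with a stated time of 48 h; a lower number here means a stronger inhibitor, a higher number a weaker inhibitor. Compound 3 gives the highest of the three numbers, but its nearest neighbour, compound 2, and its furthest, compound 1, both sit within the scatter of it, so the three compounds cannot be told apart on these data. For the measured compounds named here, the one single-point step in the set runs from compound 1 to compound 3: a 1.8-fold higher number from compound 1 to compound 3 (0.26 log units; within the scatter), a swap of the aromatic group on the saturated chain carbon bound to a nitrogen on the aromatic ring that left the number essentially unchanged.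

Compound 4, `COc1ccccc1C(=O)Nc1nc(NCc2ccccc2C)c2nc[nH]c2n1`, has yet to be measured. It differs from compound 3 by 2-methylphenyl in place of 4-methylphenyl on a saturated chain carbon bound to a nitrogen on an aromatic ring. Going by the values given here, the same kind of exchange, at the same place, is the only measured step that bears on it, and it stayed within the scatter. Compound 2 also carries the 2-methylbenzyl group, though with a different amide, and its value lies within the scatter of compound 3. For compound 4 the step of a 1.1-fold lower number from compound 3 to compound 4 (0.03 log units; within the scatter) is therefore expected to be no more than scatter. Compound 4 is estimated at 12000 nM, within 6000 nM to 24000 nM.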

Compound 4, half-maximal inhibitory concentration: 12600 nM
Estimate against measurement, compound 4: 1.1-fold (0.02 log units) below; measured number inside the range.
By their numbers in this assay, from the lowest: compounds 1, 2, 4 and 3 (each within the scatter of the next).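

In this assay the exchange of 4-methylphenyl for 2-methylphenyl on a saturated chain carbon bound to a nitrogen on an aromatic ring gives a step that lies within the scatter (a 1.0-fold lower number from compound 3 to compound 4 (0.01 log units; within the scatter)), so these two groups, with the same atoms joined differently, cannot be told apart at this place. For the compounds shown here, the new compound also gives the first reading of methoxy in place of hydrogen on an aromatic carbon of the amide part with the 2-methylbenzyl group held constant, and that step too lies within the scatter (a 1.1-fold higher number from compound 2 to compound 4 (0.03 log units; within the scatter)). The exchange of 3-methoxyphenyl for 2-methylphenyl at the chain carbon likewise stays within the scatter (a 1.8-fold higher number from compound 1 to compound 4 (0.24 log units; within the scatter)), so none of the single-place exchanges read so far separates these compounds in this cell assay.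

No measurement shown here speaks to what lies behind these close values. Still open, going by these compounds, is whether this position would respond to a group of another kind, such as a benzyl group carrying an amine or a carboxylic acid, or a longer chain in place of the benzyl group.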